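The source may report more compounds than this note shows. Statements on the series, on what has been measured and on what is new or still open speak of the compounds shown alone.

Measured in a functional assay on A549 cells (Homo sapiens) for cytotoxicity, read by MTT assay, with a stated time of 72 h; a lower number here means a stronger inhibitor, a higher number a weaker inhibitor:
- compound 1 `Cn1ccc2c(Oc3ccc(NC(=O)c4cc5cccnc5n(-c5ccccc5)c4=O)cc3F)ncnc21`: 63200 nM
- compound 2 `Cn1ccc2c(Oc3ccc(NC(=O)c4cc5cccnc5n(-c5ccc(F)cc5)c4=O)cc3F)ncnc21`: 7320 nM
- compound 3 `O=C(Nc1ccc(Oc2ncnc3[nH]ccc23)c(F)c1)c1cc2cccnc2n(-c2ccccc2)c1=O`: 45500 nM

Compound 3 holds the second highest of these three numbers. It stands level with its methylated counterpart, with a 1.4-fold lower number from compound 1 to compound 3 (0.14 log units; within the scatter), so removing that methyl leaves no change beyond the scatter. Compound 2 gives a clearly lower number than compound 3.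

The next compound is compound 4 `O=C(Nc1ccc(Oc2ncnc3[nH]ccc23)c(F)c1)c1cc2cccnc2n(-c2ccc(F)cc2)c1=O`, which differs from compound 3 by a single change: fluoro in place of hydrogen on an aromatic carbon. This is fluoro in place of hydrogen on an aromatic carbon, turning phenyl into 4-fluorophenyl.

One measured step is the same change made on the methylated series, and it gave an 8.6-fold lower number from compound 1 to compound 2 (0.94 log units; beyond the scatter). That is a single precedent, so it shows no general pattern. The step that removes the methyl, a 1.4-fold lower number from compound 1 to compound 3 (0.14 log units; within the scatter), gives no reason to expect a different outcome without the methyl. A lower number in this assay is therefore expected, of similar but slightly smaller size. The expected change is a 7.0-fold lower number from compound 3 to compound 4 (0.85 log units; beyond the scatter). For compound 4 the estimated value is 6500 nM, with an expected range of 2200 nM to 20000 nM.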

Compound 4, half-maximal inhibitory concentration: 5290 nM
Estimate against measurement, compound 4: 1.2-fold (0.09 log units) above, within the range that was stated.
By their numbers in this assay, from the lowest: compounds 4 and 2 (each within the scatter of the next); then compounds 3 and 1 (each within the scatter of the next).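

In this assay, the change from phenyl to 4-fluorophenyl gives an 8.6-fold lower number from compound 3 to compound 4 (0.93 log units; beyond the scatter), so the drop previously seen only with the methyl on the aromatic nitrogen also appears with hydrogen there, and at a matching size: the same change on two cores in this assay, an 8.6-fold lower number (0.94 log units; beyond the scatter) from compound 1 to compound 2 and an 8.6-fold lower number (0.93 log units; beyond the scatter) from compound 3 to compound 4, 1.0-fold (0.00 log units) apart, within the scatter of two such steps

The methyl also still makes no difference beyond the scatter when the 4-fluorophenyl is present, with a 1.4-fold lower number from compound 2 to compound 4 (0.14 log units; within the scatter), repeating what was seen with the unsubstituted phenyl: the same change on two cores in this assay, a 1.4-fold lower number (0.14 log units; within the scatter) from compound 1 to compound 3 and a 1.4-fold lower number (0.14 log units; within the scatter) from compound 2 to compound 4, 1.0-fold (0.00 log units) apart, within the scatter of two such steps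

Across these four compounds, the two changes therefore read as independent of each other, with the number following the fluoro and not the methyl, and none of the four goes against this.

The compounds shown carry only hydrogen or fluoro at this place on the ring, so they leave open whether chloro, methoxy or an amine there would give a step of similar size. They also leave open whether the same step would hold on a core changed elsewhere, and what the fluoro does on any other carbon of that ring.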